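Allyl gives way to a nitroimidazole on sulfur

The compounds below may be only part of what the source reports. "The series", "measured", "known", "first", "only" and "open" are said of these compounds alone.

Measured in a functional assay on L1210 cells (Mus musculus) for inhibition; a higher number here means that more compound is needed for the effect, a lower number that less compound is needed:
Compound 1 `C=CCSc1nc(N)nc2c1ncn2[C@@H]1C[C@H](O)[C@@H](CO)O1`: > 100 uM, a limit and not a number
Compound 2 `C=CCSc1nc(N)nc2c1ncn2[C@H]1C[C@H](O)[C@@H](CO)O1`: 3 uM

In this assay, going by the values given here, compound 2 gives the only actual number so far, 3 uM. Compound 3 `Cn1cnc([N+](=O)[O-])c1Sc1nc(N)nc2c1ncn2[C@H]1C[C@H](O)[C@@H](CO)O1` keeps the drawn configuration of compound 2 and changes the group on sulfur: 1-methyl-4-nitro-1H-imidazol-5-yl in place of allyl on a sulfur. Among the compounds with values here, the one measured step, an at least 33-fold lower number from compound 1 to compound 2 (1.52 log units; beyond the scatter), was large, but it concerns configuration alone (the fact that compounds 1 and 2 differ only in the configuration as drawn). Within the data shown here, no measured step changes the group on sulfur, so no step beyond the scatter is expected, and the range stays wide. The expected step is a 1.3-fold higher number from compound 2 to compound 3 (0.12 log units; within the scatter). Compound 3 is estimated at 4 uM, with an expected range of 0.8 uM to 20 uM.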

Compound 3, concentration for half-maximal effect: 11 uM
Beside the measured number, compound 3's estimate is 2.8-fold (0.44 log units) below it; the range from low to high includes it.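

Going by these compounds alone, changing the group on sulfur is now measured for the first time: in this assay the step is a 3.7-fold higher number from compound 2 to compound 3 (0.56 log units; beyond the scatter), a modest change. Activity in this assay therefore responds to the group at this position, yet the much larger 1-methyl-4-nitro-1H-imidazol-5-yl group is accepted in place of allyl at a limited cost. Nothing shown accounts for the size of this step.

Within the data shown here, with only two groups on sulfur, it stays open whether the nitro group, the methyl group or the ring itself drives the step. On these data alone, how a benzyl group or a longer alkyl chain would compare also stays open.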